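This account rests on a few compounds, and the source may have more. Where it says the series, first, only, none or still open, it means among the compounds named here.

The compounds share one core. Compound 1 `c1ccc(OCc2noc(-c3ccc(C4=NCCN4)cc3)n2)cc1`, compound 2 `CC(C)(C)c1ccc(-c2noc(-c3ccc(C4=NCCN4)cc3)n2)cc1` and compound 3 `c1ccc(Oc2ccc(-c3noc(-c4ccc(C5=NCCN5)cc4)n3)cc2)cc1` have been measured in an assay for inhibition of Amine oxidase [flavin-containing] A (Homo sapiens), read by fluorescence and spectrophotometry, using microsomes, with stated times of 30 min and 20 min; a higher number here means a weaker inhibitor, a lower number a stronger inhibitor. For compound 1 the assay reports only a limit, > 100000 nM; this is the limit (the limit of > 100000 nM in this assay, at which 1 of the 3 values shown sits). Compound 2 gives 751 nM and compound 3 gives 2770 nM. Putting phenoxy where tert-butyl stood gives a 3.7-fold higher number from compound 2 to compound 3 (0.57 log units; beyond the scatter), so both aryl groups on the core stay well away from the limit. Compound 4 `COc1cccc(-c2noc(-c3ccc(C4=NCCN4)cc3)n2)c1` rearranges the atoms of compound 1: 3-methoxyphenyl in place of phenoxymethyl on an aromatic carbon. Within the data shown here, no measured step covers this change; compounds 2 and 3 only show what aryl groups on the core give. An estimated value for compound 4 is 2000 nM, in the range 500 nM to 10000 nM. The expected step, an at least 50-fold lower number from compound 1 to compound 4 (1.69 log units; beyond the scatter), starts from a limit and so its size stays uncertain.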

Compound 4, half-maximal inhibitory concentration: 12000 nM
Compound 4: middle estimate off by 6.0-fold (0.78 log units), on the low side, outside the stated range (above it).
By their numbers in this assay, from the lowest: compound 2; then compound 3; then compound 4. At a limit, above all of these: compound 1.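

In this assay 3-methoxyphenyl in place of phenoxymethyl gives an at least 8.3-fold lower number from compound 1 to compound 4 (0.92 log units; beyond the scatter) at this carbon of the shared core. The two groups match in every count given, so how the atoms are joined matters here and not just which atoms are present. Going by these compounds, the full size of this step stays unknown, because compound 1 gives only a limit: the limit of > 100000 nM in this assay, at which 1 of the 4 values shown sits. Still open, on these data alone, is how an amine or a carboxylic acid on the aromatic ring of 3-methoxyphenyl would compare with the methoxy group of compound 4.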